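The source may report more compounds than this note shows. Statements on the series, on what has been measured and on what is new or still open speak of the compounds shown alone.

Measured so far in a functional assay (Sus scrofa) with sulfonylurea receptors; K-ATP channels (Homo sapiens) as the target; on this read-out lower numbers stand for an effect already at smaller amounts and higher numbers for an effect only at larger amounts of compound: compound 1 `CC(=O)Nc1c(C(O)(C(F)(F)F)C(F)(F)F)ccc2ccccc12` gives 95.5 nM. Compound 2 `O=C(Nc1c(C(O)(C(F)(F)F)C(F)(F)F)ccc2ccccc12)C1CCC1` gives 81.3 nM. Compound 3 `O=C(Nc1c(C(O)(C(F)(F)F)C(F)(F)F)ccc2ccccc12)c1ccc(Cl)cc1` gives 389 nM.

Compound 3 stands at the highest of these three numbers. The step from compound 1 to compound 2 was a 1.2-fold lower number from compound 1 to compound 2 (0.07 log units; within the scatter), whereas the move to the aromatic amide was a 4.1-fold higher number from compound 1 to compound 3 (0.61 log units; beyond the scatter) and a 4.8-fold higher number from compound 2 to compound 3 (0.68 log units; beyond the scatter), both modest but real. Compound 4 `O=C(Nc1c(C(O)(C(F)(F)F)C(F)(F)F)ccc2ccccc12)c1cccnc1` differs from compound 3 in one place: pyridin-3-yl in place of 4-chlorophenyl on a carbonyl carbon. For the measured compounds named here, no measured step exchanges one aromatic ring for another, so the prior steps only show that the aromatic amide of compound 3 sits weaker than the small alkyl amides. The expected step in this assay is therefore a 1.4-fold higher number from compound 3 to compound 4 (0.15 log units; within the scatter), a slight rise that may not exceed the scatter. Compound 4 is estimated at 550 nM, with an expected range from 150 nM to 1800 nM.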

Compound 4, half-maximal effective concentration: 617 nM
Compound 4: middle estimate off by 1.1-fold (0.05 log units), on the low side; low and high end bracket the measured number.
By their numbers in this assay, from the lowest: compounds 2 and 1 (each within the scatter of the next); then compounds 3 and 4 (each within the scatter of the next).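

In this assay, swapping one aromatic ring for another on this carbonyl carbon gives a 1.6-fold higher number from compound 3 to compound 4 (0.20 log units; within the scatter), so adding a ring nitrogen and removing the chlorine shifts the number no more than repeat measurements would. The second aromatic amide also sits clearly above the small alkyl amides, with a 6.5-fold higher number from compound 1 to compound 4 (0.81 log units; beyond the scatter) and a 7.6-fold higher number from compound 2 to compound 4 (0.88 log units; beyond the scatter), so the gap seen with compound 3 is not unique to 4-chlorophenyl. Nothing measured here explains that gap.

On these data alone, it remains open how a longer chain would behave at this carbonyl carbon. Also open, as far as these compounds go, is whether an amine or a carboxylic acid on the aromatic ring would bring the number closer to those of compound 1 and compound 2.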